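A few compounds are considered here, and "the series" means these few. Any claim that something is new, unique, unknown or untested is made for them only; others in the source may bear on it.

Measured in an ADME assay on microsomes from liver (Rattus norvegicus) for metabolic stability, using NADPH; on this read-out higher numbers stand for fast clearance and lower numbers for slow clearance:

- compound 1 `COC(=O)c1nc(-c2ccco2)c(C(F)(F)F)cc1N`: > 0.7 mL/min/kg, a limit of the assay and not a number
- compound 2 `CNC(=O)c1nc(Br)c(C(F)(F)F)cc1N`: 0.1 mL/min/kg
- compound 3 `CC(O)CNC(=O)c1nc(Br)c(C(F)(F)F)cc1N`: 0.0377 mL/min/kg

Only compound 2 and compound 3 have actual numbers here, and compound 3, at 0.0377 mL/min/kg, has the lower of the two. Among the measured compounds shown here, compound 1 is reported only as a limit, so it gives no step to work with.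

The next compound, compound 4 `Nc1cc(C(F)(F)F)c(Br)nc1C(=O)NC[C@@H](O)C(F)(F)F`, keeps the core of compound 3 and alters only its side chain: 2,2,2-trifluoro-1-hydroxyethyl in place of 1-hydroxyethyl on a saturated chain carbon bound to an amide-type nitrogen. Put simply, 2,2,2-trifluoro-1-hydroxyethyl takes the place of 1-hydroxyethyl on a saturated chain carbon bound to an amide-type nitrogen.

For the measured compounds named here, one measured step bears on this place: a 2.7-fold lower number from compound 2 to compound 3 (0.42 log units; beyond the scatter). That step is modest, though beyond the scatter, and it introduced 1-hydroxyethyl in place of hydrogen. Going by the values given here, no measured step shows what the fluorines do in this assay, so this evidence is indirect. With so little to go on, no step beyond the scatter is expected in either direction. The estimated step is a 1.1-fold higher number from compound 3 to compound 4 (0.03 log units; within the scatter). The expected value for compound 4 is 0.04 mL/min/kg, with an estimated range from 0.015 mL/min/kg to 0.12 mL/min/kg.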

Compound 4, clearance: 0.0371 mL/min/kg
Compound 4: middle estimate off by 1.1-fold (0.03 log units), on the high side, and the stated range covers the measured number.
By their numbers in this assay, from the lowest: compounds 4 and 3 (each within the scatter of the next); then compound 2. At a limit, above all of these: compound 1.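

In this assay, putting 2,2,2-trifluoro-1-hydroxyethyl in place of 1-hydroxyethyl on a saturated chain carbon bound to an amide-type nitrogen gives a 1.0-fold lower number from compound 3 to compound 4 (0.01 log units; within the scatter), so at this place the three added fluorine atoms leave the number where it was. Measured against plain hydrogen at the same place, the fluorinated group gives a 2.7-fold lower number from compound 2 to compound 4 (0.43 log units; beyond the scatter), the same size as a 2.7-fold lower number from compound 2 to compound 3 (0.42 log units; beyond the scatter), so the modest step down from compound 2 now holds for two different side chains rather than one. Nothing measured here offers an explanation for why the fluorine atoms make no visible difference in this read-out.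

On these data alone, both side chains carry a hydroxyl group, so it remains open whether that group matters at all, and an amine in its place, or a longer chain carrying it, could show whether the number depends on it. Also open, as far as these compounds go, is whether these side chains would give the same result with a chlorine atom or a nitrile in place of the bromine on the shared core.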